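Chain shortening at the limit of a cytotoxicity read-out

This account rests on a few compounds, and the source may have more. Where it says the series, first, only, none or still open, it means among the compounds named here.

Measured in a functional assay on PANC-1 cells (Homo sapiens) for cytotoxicity, read by WST assay, with a stated time of 24 h; a lower number here means a stronger inhibitor, a higher number a weaker inhibitor:
Compound 1 `O=C(/C=C/CCCCCCc1ccccc1)N1CCCC1` gives > 100000 nM (a limit)
Compound 2 `O=C(/C=C/CCCCCCc1ccccc1)N1CCC(O)CC1` gives > 100000 nM (a limit)
Compound 3 `O=C(CCCCCCCCc1ccccc1)N1CCCCC1` gives > 100000 nM (a limit)

Compound 3 stands at a limit (> 100000 nM) and has no number of its own. Compound 4 `O=C(CCCCCCCc1ccccc1)N1CCCCC1` differs from it by phenyl in place of benzyl on a saturated chain carbon, seven bonds along the chain from a carbonyl carbon. Going by the values given here, the one measured step, a step that the two limits leave unreadable from compound 1 to compound 2, lies at another place and has no readable size, so it gives no measure for this change. Compound 4 is expected to reach a limit again in this assay because of the limit of > 100000 nM in this assay, at which 3 of the 3 values shown sit, and compound 3 sits there too (> 100000 nM). The expected step of a number no higher from compound 3 to compound 4 (the limit leaves the size open) is none beyond the scatter, with no direction foreseen. Compound 4 is estimated at 100000 nM, with an expected range from 40000 nM to 200000 nM.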

Compound 4, half-maximal inhibitory concentration: > 100000 nM
Compound 4 ended at the assay's limit; the forecaster's own chance of this, stated with the estimate: 85%; the middle value sits exactly at the limit.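

Compound 3 and compound 4 both stand at a limit in this assay, and the step between them cannot be read. The compounds shown leave open whether any change to them would yield a measurable value, since all remain at one limit: the limit of > 100000 nM in this assay, at which 4 of the 4 values shown sit.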